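Piperidinyl for vinyl on the oxazole-bearing indole

This account rests on a few compounds, and the source may have more. Where it says the series, first, only, none or still open, it means among the compounds named here.

Among the measured compounds shown here, compound 2 `C=Cc1nc(-c2c[nH]c3ccccc23)co1` stands highest of the two numbers measured so far in a functional assay on PC-3 cells (Homo sapiens) for cytotoxicity, read by MTT assay, with a stated time of 48 h (a higher number here means a weaker inhibitor, a lower number a stronger inhibitor), where compound 2 gives 426000 nM. Its nearest neighbour is compound 1 `c1ccc2c(-c3coc(-c4ccncc4)n3)c[nH]c2c1`, which in this assay gives 298000 nM; the step of a 1.4-fold higher number from compound 1 to compound 2 (0.16 log units; within the scatter) lies within the scatter, so the two compounds cannot be told apart on these numbers.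

Compound 3 `c1ccc2c(-c3coc(C4CCNCC4)n3)c[nH]c2c1` is the unmeasured member. It differs from compound 2 in one place: piperidin-4-yl in place of vinyl on an aromatic carbon. For the measured compounds named here, the only measured step that bears on this change is a 1.4-fold higher number from compound 1 to compound 2 (0.16 log units; within the scatter), which exchanged a six-membered aromatic nitrogen ring for the vinyl group at the same position without moving the number beyond the scatter. Since the piperidin-4-yl group of compound 3 again places a six-membered nitrogen ring there, no step beyond the scatter is expected in this assay from compound 2 to compound 3, and the estimated step is a 1.3-fold lower number from compound 2 to compound 3 (0.12 log units; within the scatter). Compound 3 is therefore expected to give about 320000 nM in this assay, with a likely range from 110000 nM to 950000 nM.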

Compound 3, half-maximal inhibitory concentration: 407000 nM
Compound 3: middle estimate off by 1.3-fold (0.10 log units), on the low side, within the range that was stated.
By their numbers in this assay, from the lowest: compounds 1, 3 and 2 (each within the scatter of the next).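

Among the compounds shown here, at this position, on an aromatic carbon of a five-membered aromatic ring with 1 nitrogen and 1 oxygen, the earlier compounds had compared only the aromatic pyridin-4-yl with vinyl, whereas compound 3 brings in a non-aromatic six-membered ring carrying a hydrogen-bond donor. In this assay, the results show a 1.0-fold lower number from compound 2 to compound 3 (0.02 log units; within the scatter) and a 1.4-fold higher number from compound 1 to compound 3 (0.14 log units; within the scatter), so pyridin-4-yl, vinyl and piperidin-4-yl cannot be told apart, even though piperidin-4-yl has more heavy atoms than vinyl and differs from pyridin-4-yl in its ring type. No available evidence accounts for this lack of separation among the three compounds.

The three compounds leave open whether any group at this position can move the number in this assay beyond the scatter, for instance a carboxylic acid, a primary amine on a longer chain, or a small alkyl group such as methyl. They also do not settle whether the ring nitrogen of piperidin-4-yl matters at all, a question that cyclohexyl, its all-carbon counterpart, or a piperidine bearing a methyl group on that nitrogen would address.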